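Fluorine on the aryl group of a fused-core nucleoside series

The compounds below may be only part of what the source reports. "The series", "measured", "known", "first", "only" and "open" are said of these compounds alone.

Compound 2 `Nc1ncnn2c([C@@H]3O[C@H](CO)[C@@H](O)[C@H]3O)cc(C#Cc3ccccc3)c12` gives 37700 nM in a functional assay on CAPAN-1 cells (Homo sapiens) for antiproliferative activity, with a stated time of 72 h; a lower number here means a stronger inhibitor, a higher number a weaker inhibitor. Compound 1 `Nc1ncnn2c([C@@H]3O[C@H](CO)[C@@H](O)[C@H]3O)cc(C#Cc3ccc(F)cc3)c12` gives 55400 nM. The change fluoro in place of hydrogen on an aromatic carbon made a step of a 1.5-fold higher number from compound 2 to compound 1 (0.17 log units; within the scatter). Compound 3 `Nc1ncnn2c([C@@H]3O[C@H](CO)[C@@H](O)[C@H]3O)cc(-c3ccccc3F)c12` reaches only the limit of this assay, > 100000 nM. The cores of compounds 2 and 3 differ by 2-fluorophenyl in place of 2-phenylethynyl on an aromatic carbon, a step of an at least 2.6-fold higher number from compound 2 to compound 3 (0.42 log units; beyond the scatter). Compound 4 `Nc1ncnn2c([C@@H]3O[C@H](CO)[C@@H](O)[C@H]3O)cc(-c3ccc(F)cc3F)c12` differs from compound 3 by fluoro in place of hydrogen on an aromatic carbon; here the fluoro is meta to a fluoro group, so this is the same kind of change as from compound 2 to compound 1, not the same. Compound 4 is expected to make a step that the limit leaves unreadable from compound 3 to compound 4, resting on the small step of a 1.5-fold higher number from compound 2 to compound 1 (0.17 log units; within the scatter) and on compound 3 standing at the limit of > 100000 nM in this assay, at which 1 of the 3 values shown sits. The estimate for compound 4 in this assay is 150000 nM, between 60000 nM and 400000 nM.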

Compound 4, half-maximal inhibitory concentration: 50900 nM
Compound 4: middle estimate off by 2.9-fold (0.47 log units), on the high side; measured number outside the range, below it.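

The fluoro change did not carry over unchanged from the core of compound 2 to the core of compound 3 in this assay: the same change on two cores in this assay, a 1.5-fold higher number (0.17 log units; within the scatter) from compound 2 to compound 1 and an at least 1.9-fold lower number (0.29 log units; that floor lies within the scatter) from compound 3 to compound 4, at least 2.8-fold (0.46 log units) apart, beyond the scatter of two such steps. The second step, an at least 1.9-fold lower number from compound 3 to compound 4 (0.29 log units; that floor lies within the scatter), is only a floor, and compound 3 stands at a limit of the assay rather than at a number: the limit of > 100000 nM in this assay, at which 1 of the 4 values shown sits. Replacing the ethynyl group with 2,4-difluorophenyl gives a 1.4-fold higher number from compound 2 to compound 4 (0.13 log units; within the scatter) and a 1.1-fold lower number from compound 1 to compound 4 (0.04 log units; within the scatter), so these pairs cannot be told apart, and nothing here shows why the fluoro step differs between the two cores.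

The compounds shown leave open whether the fluoro step would hold on a third core. They also leave open how an amine or a carboxylic acid in place of the new fluoro would read in this assay.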